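The compounds below may be only part of what the source reports. "The series", "measured", "known", "first", "only" and "open" are said of these compounds alone.

Measured compounds:
Compound 1 `CCNCCCOc1ccc2cc(NC(=O)c3ccc(O)c(CC=C(C)C)c3)c(=O)oc2c1C` gives 980 nM in a functional assay on MCF7 cells (Homo sapiens) for antiproliferative activity; on this read-out higher numbers stand for weaker inhibition and lower numbers for stronger inhibition.
Compound 2 `CC(C)=CCc1cc(C(=O)Nc2cc3ccc(OCCCNCC(C)C)c(C)c3oc2=O)ccc1O` gives 1320 nM in this assay.

Compound 2 stands at the higher of the two numbers, with compound 1 nearest to it; the step of a 1.3-fold higher number from compound 1 to compound 2 (0.13 log units; within the scatter) is within the scatter, so the two compounds cannot be told apart on this read-out. The next compound, compound 3 `COC(=O)CNCCCOc1ccc2cc(NC(=O)c3ccc(O)c(CC=C(C)C)c3)c(=O)oc2c1C`, differs from compound 2 in one place: methoxycarbonyl in place of isopropyl on a saturated chain carbon bound to an amine nitrogen. For the measured compounds named here, no measured step involves a methoxycarbonyl group, so the only guidance is the step of a 1.3-fold higher number from compound 1 to compound 2 (0.13 log units; within the scatter), which shows that exchanging one saturated group for another on the chain carbon bound to the amine nitrogen left the number within the scatter. On that basis compound 3 is expected to stay close to compound 2, and the step of a 1.1-fold higher number from compound 2 to compound 3 (0.06 log units; within the scatter) is estimated to fall within the scatter or only just beyond it. For compound 3 the estimate in this assay is 1500 nM, with a range from 600 nM to 4000 nM.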

Compound 3, half-maximal inhibitory concentration: 2820 nM
Compound 3: middle estimate off by 1.9-fold (0.27 log units), on the low side; measured number inside the range.
By their numbers in this assay, from the lowest: compounds 1 and 2 (each within the scatter of the next); then compound 3.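

In this assay, the saturated chain carbon bound to an amine nitrogen turns out not to accept every group without a change in the number: methoxycarbonyl in place of isopropyl gives a 2.1-fold higher number from compound 2 to compound 3 (0.33 log units; beyond the scatter), and methoxycarbonyl in place of methyl gives a 2.9-fold higher number from compound 1 to compound 3 (0.46 log units; beyond the scatter). Methyl and isopropyl could not be told apart here, so methoxycarbonyl, which brings oxygen atoms, a double bond outside aromatic rings and hydrogen-bond acceptors to this place, is the first group shown to move the number beyond the scatter, though only modestly and towards weaker inhibition. Nothing available explains this shift.

With a single group of this kind at this place, the compounds shown leave open whether the weaker inhibition belongs to the ester as a whole or to some part of it. A carboxylic acid, a primary amide, a hydroxyethyl group or a longer chain ending in the same ester would each separate these possibilities, and a larger saturated group would show how far the tolerance seen with methyl and isopropyl extends.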